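Swapping the methoxyphenyl arm for a fluorophenyl one

This account rests on a few compounds, and the source may have more. Where it says the series, first, only, none or still open, it means among the compounds named here.

Measured so far:
- compound 1 `COc1ccc(-c2cn3ccnc3c(-c3ccc4ncn(C5CCCCC5)c4c3)n2)cc1`: 78.8%
- compound 2 `c1ccc2c(-c3cn4ccnc4c(-c4ccc5ncn(C6CCCCC6)c5c4)n3)cccc2c1`: 4.46%
- compound 3 `CC(=O)c1ccc(-c2cn3ccnc3c(-c3ccc4ncn(C5CCCCC5)c4c3)n2)cc1`: 18.8%

In a functional assay on HCT-15 cells (Homo sapiens) for inhibition, read by sulforhodamine B assay, with a stated time of 48 h, tested at 10 uM (a lower number here means less inhibition, a higher number more inhibition at the concentration tested (going by the name of the read-out)), compound 1 stands highest of the three, with compound 3 nearest and compound 2 furthest. Compound 4 `Fc1ccccc1-c1cn2ccnc2c(-c2ccc3ncn(C4CCCCC4)c3c2)n1` differs from compound 1 by 2-fluorophenyl in place of 4-methoxyphenyl on an aromatic carbon. Two steps from compound 1 bear on this: a number 74.3 percentage points lower from compound 1 to compound 2 (beyond the scatter) and a number 60 percentage points lower from compound 1 to compound 3 (beyond the scatter), both large losses when the 4-methoxyphenyl group was replaced. Within the data shown here, no step involves a fluorine, so the size is uncertain, but the shared direction suggests a large drop in this assay. The expected step is a number 48.8 percentage points lower from compound 1 to compound 4 (beyond the scatter). Compound 4 is therefore estimated to reach 30%, within 5% to 65%.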

Compound 4, a percentage reported as inhibition, at one concentration (the size of the read-out at that concentration, not a potency): 6.18%
Compound 4: the middle estimate sits 23.8 percentage points above what was measured, and the stated range covers the measured number.
By their numbers in this assay, from the lowest: compounds 2 and 4 (each within the scatter of the next); then compound 3; then compound 1.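

In this assay, a third replacement of the 4-methoxyphenyl arm gives a number 72.6 percentage points lower from compound 1 to compound 4 (beyond the scatter), so the loss at this position extends beyond the naphthalen-1-yl and 4-acetylphenyl groups. The 2-fluorophenyl group also gives a number 12.6 percentage points lower from compound 3 to compound 4 (beyond the scatter), while a number 1.7 percentage points higher from compound 2 to compound 4 (within the scatter) leaves it indistinguishable from naphthalen-1-yl here. Nothing available explains these differences.

Still open, on these data alone, is whether the loss follows the change of group or its place on the phenyl ring. A 4-fluorophenyl or 2-methoxyphenyl arm would separate the two, and a 4-aminophenyl arm would test another group at that place.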